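The source may report more compounds than this note shows. Statements on the series, on what has been measured and on what is new or still open speak of the compounds shown alone.

Of the compounds shown here, three have been measured so far. Compound 1 `COc1ccc(-c2cc(/C=C/C(=O)c3ccc(N)cc3)[nH]n2)cc1` gives 1840 nM in a functional assay on NCI-H322M cells (Homo sapiens) for inhibition, read by sulforhodamine B assay, with a stated time of 48 h; on this read-out lower numbers stand for stronger inhibition of growth and higher numbers for weaker inhibition of growth. Compound 2 `COc1cc(-c2cc(/C=C/C(=O)c3ccc(N)cc3)[nH]n2)cc(OC)c1OC` gives 2230 nM in this assay, the second highest of the three numbers; its nearest neighbour is compound 1, within the scatter, and its furthest is compound 3 `COc1cc(-c2cc(/C=C/C(=O)c3ccc(Cl)c(Cl)c3)[nH]n2)cc(OC)c1OC`, which gives 14500 nM. Going by the values given here, the only single-change step among them, a 6.5-fold higher number from compound 2 to compound 3 (0.81 log units; beyond the scatter), concerns the group on the carbonyl carbon, a different part of the molecule, and so does not bear directly on the change now in question. Compound 4 `COc1ccc(-c2cc(/C=C/C(=O)c3ccc(N)cc3)[nH]n2)cc1OC` differs from compound 2 by hydrogen in place of methoxy on an aromatic carbon. Among the compounds with values here, no measured step removes a methoxy from this ring; the nearest guide is that compound 1 and compound 2, which differ from each other only in methoxy groups on this same ring, lie within the scatter of each other. The expected step of a 1.1-fold lower number from compound 2 to compound 4 (0.05 log units; within the scatter) is therefore none beyond the scatter. Compound 4 is thus expected to give about 2000 nM, within a range from 900 nM to 4500 nM.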

Compound 4, concentration for 50% growth inhibition: 4340 nM
Compound 4: middle estimate off by 2.2-fold (0.34 log units), on the low side, and the stated range covers the measured number.
By their numbers in this assay, from the lowest: compounds 1, 2 and 4 (each within the scatter of the next, the first and the last beyond it); then compound 3.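

In this assay, this carbon, ortho to a methoxy group and meta to a large group, can now be read from two sides. Hydrogen in place of methoxy on compound 2 gives a 1.9-fold higher number from compound 2 to compound 4 (0.29 log units; within the scatter) and so shows no firm change, whereas methoxy in place of hydrogen on compound 1 gives a 2.4-fold higher number from compound 1 to compound 4 (0.37 log units; beyond the scatter) and is a modest loss of growth inhibition beyond the scatter. Going by these compounds alone, a methoxy at this carbon therefore has no large effect in either pair, and only the pair with compound 1 shows any clear effect at all. Nothing measured here explains either step.

The compounds shown leave open how a hydroxyl group, a fluorine atom or a longer ethoxy chain would behave on this carbon, and whether the modest step from compound 1 holds with other groups on the carbonyl carbon.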